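The compounds below may be only part of what the source reports. "The series", "measured", "known", "first", "only" and "open" are said of these compounds alone.

Measured compounds:
- compound 1 `Nc1nn(C(=O)Nc2ccc(Cc3ccccc3)cc2)c2ccccc12`, which in a functional assay on NCI-H322M cells (Homo sapiens) for inhibition, read by sulforhodamine B assay, with a stated time of 48 h (on this read-out lower numbers stand for stronger inhibition of growth and higher numbers for weaker inhibition of growth), gives 27800 nM.
- compound 2 `COc1ccccc1NC(=O)n1nc(N)c2ccccc21`, which in this assay gives > 100000 nM, a limit of the assay rather than a number.

Compound 1 therefore stands as the only numerical result in this assay; the other entry is a limit, as noted in the limit of > 100000 nM in this assay, at which 1 of the 2 values shown sits. Compound 3 `CCCCOc1ccc(NC(=O)n2nc(N)c3ccccc32)cc1` has not yet been tested in this assay. It differs from compound 1 in a single place: butoxy in place of benzyl on an aromatic carbon. For the measured compounds named here, since no measured pair of compounds differing in one place is available, the size of this change can only be anticipated. The expected step from compound 1 to compound 3 is a 1.4-fold higher number from compound 1 to compound 3 (0.16 log units; within the scatter), a modest weakening that may not exceed the usual scatter. Compound 3 is accordingly estimated at 40000 nM in this assay, with a likely range from 12000 nM to 130000 nM.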

Compound 3, concentration for 50% growth inhibition: 20600 nM
Beside the measured number, compound 3's estimate is 1.9-fold (0.29 log units) above it; measured number inside the range.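

In this assay, butoxy in place of benzyl on this aromatic carbon, para to a large group, gives a 1.3-fold lower number from compound 1 to compound 3 (0.13 log units; within the scatter). The earlier compounds shown here offered no such comparison; this pair shows that an open chain carrying an oxygen can stand where a group with a carbon-only aromatic ring stood, with no change that can be told from repeat measurement. Compound 2 remains a limit of the assay rather than a number: the limit of > 100000 nM in this assay, at which 1 of the 3 values shown sits.

On these data alone, whether a shorter chain such as ethoxy, a longer one such as octyloxy, or an amine at this position would move the number beyond the scatter stays open. A single pair also cannot show why the two numbers lie so close, or whether the same holds at other positions on this ring.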